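The source may report more compounds than this note shows. Statements on the series, on what has been measured and on what is new or still open speak of the compounds shown alone.

The measured compounds in a functional assay on MDA-MB-231 cells (Homo sapiens) for cytotoxicity, read by MTT assay, with a stated time of 48 h; on this read-out higher numbers stand for weaker inhibition and lower numbers for stronger inhibition:

compound 1 `Nc1nc(-c2ccccc2)cn1/N=C/c1cc2ccccc2nc1Cl`: 49000 nM
compound 2 `Cc1ccc(-c2cn(/N=C/c3cc4ccccc4nc3Cl)c(N)n2)cc1`: the reading for compound 2 is a limit of the assay, > 50000 nM

Compound 2 thus stands only at a limit; the reading the limit of > 50000 nM in this assay, at which 1 of the 2 values shown sits, is where it sits, and no number is known for it. Within the data shown here, the single measured step, an at least 1.0-fold higher number from compound 1 to compound 2 (0.00 log units; that floor lies within the scatter), lies within the scatter, so the pair offers no direction. Compound 3 `COc1ccc(-c2cn(/N=C/c3cc4ccccc4nc3Cl)c(N)n2)cc1` differs from compound 2 by methoxy in place of methyl on an aromatic carbon. Among the measured compounds shown here, no measured step involves a methoxy group, so nothing among the measured compounds points to a gain or a loss. Compound 3 is therefore expected to remain near the limit in this assay, and the expected step is a number no higher from compound 2 to compound 3 (the limit leaves the size open). Compound 3 is estimated at 50000 nM, with a range from 25000 nM to 100000 nM, and a limit reading rather than a number is the more likely outcome.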

Compound 3, half-maximal inhibitory concentration: > 50000 nM
Compound 3 was reported as a limit; the forecaster's own chance of this, stated with the estimate: 60%; the middle value lies on the limit itself.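

In this assay, methoxy on this aromatic carbon, para to a large group, leaves the reading at a limit of the assay, just as methyl does, and with compound 2 and compound 3 both at a limit, the step between them cannot be read. Methoxy in place of hydrogen gives an at least 1.0-fold higher number from compound 1 to compound 3 (0.00 log units; that floor lies within the scatter), so this change, like the methyl change, offers no direction. Two different groups at this place now end at the same reading: the limit of > 50000 nM in this assay, at which 2 of the 3 values shown sit.

Going by these compounds, whether an amine, a carboxylic acid or a chlorine on this aromatic carbon would give a number rather than a limit stays open. Also open, on these data alone, is where compound 2 and compound 3 truly lie, so no order can be given for them.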